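The compounds below may be only part of what the source reports. "The series", "measured", "known", "first", "only" and "open" are said of these compounds alone.

In an in vitro ADME assay on microsomes from liver (Homo sapiens) for metabolic stability, tested at 5 uM (on this read-out lower numbers stand for a shorter-lived compound and higher numbers for a longer-lived compound), compound 2 `CC(C)CCn1nc(-c2cccs2)c(O)c(C2=NS(=O)(=O)c3cc(OCC(=O)NO)ccc3N2)c1=O` gives > 1 h, which is a limit of the assay and not a number. Compound 2 therefore stands at the limit of > 1 h in this assay, at which 1 of the 2 values shown sits. Its closest measured relative, compound 1 `CC(C)CCn1nc(-c2cccs2)c(O)c(C2=NS(=O)(=O)c3cc(OC(C)C(N)=O)ccc3N2)c1=O`, gives 0.217 h in this assay.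

The next structure, compound 3 `CC(C)CCn1nc(-c2cccs2)c(O)c(C2=NS(=O)(=O)c3cc(C4CCCC4=O)ccc3N2)c1=O`, differs from compound 2 in one place: 2-oxocyclopentyl in place of (hydroxycarbamoyl)methoxy on an aromatic carbon. In words, 2-oxocyclopentyl takes the place of (hydroxycarbamoyl)methoxy on an aromatic carbon.

For the measured compounds named here, only one measured step bears on this change: an at least 4.6-fold higher number from compound 1 to compound 2 (0.66 log units; beyond the scatter). It came with (hydroxycarbamoyl)methyl in place of 1-carbamoylethyl on an oxygen on an aromatic ring. Compound 3 gives up the hydroxycarbamoyl group that compound 2 carries, and compound 1, which also lacks that group, gives 0.217 h. A shorter half-life is therefore expected, although this single comparison is a weak guide, as the incoming group appears in neither measured compound. The estimated change is an at least 2.5-fold lower number from compound 2 to compound 3 (0.39 log units; beyond the scatter), a step downward. Compound 3 is expected at about 0.4 h, with an estimated range of 0.12 h to 1.2 h.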

Compound 3, half-life: 0.733 h
For compound 3 the middle estimate is 1.8-fold (0.26 log units) below the measured one; the range from low to high includes it.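

In this assay, compound 3 has neither the hydroxycarbamoyl group nor the oxygen that links the side chain to the aromatic carbon, yet the change from the 1-carbamoylethoxy group gives a 3.4-fold higher number from compound 1 to compound 3 (0.53 log units; beyond the scatter). A longer half-life than that of compound 1 therefore does not depend on the hydroxycarbamoyl group, which the first comparison could not show. The comparison with the hydroxycarbamoyl compound reads an at least 1.3-fold lower number from compound 2 to compound 3 (0.13 log units; that floor lies within the scatter), so it gives only a floor, and that floor does not separate the two compounds. Compound 2 carries a limit of the assay and not a number: the limit of > 1 h in this assay, at which 1 of the 3 values shown sits.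

Still open, as far as these compounds go, is whether the longer half-life of compound 3 goes with the five-membered ring or with its carbonyl, and how 2-oxocyclopentyl compares with a plain cyclopentyl, an amine or a carboxylic acid on the same aromatic carbon. Three compounds on one shared core also cannot tell whether the gap between the 2-oxocyclopentyl and 1-carbamoylethoxy groups would persist on a different core.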